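A few compounds are considered here, and "the series" means these few. Any claim that something is new, unique, unknown or untested is made for them only; others in the source may bear on it.

For the measured compounds named here, compound 3 `Cn1cc(C2=C(c3nn(CCCN4CCCCC4)c4ncccc34)C(=O)NC2=O)c2ccccc21` gives 7670 nM in a functional assay on SMMC-7721 cells (Homo sapiens) for antiproliferative activity, read by MTT assay, with a stated time of 48 h (on this read-out higher numbers stand for weaker inhibition and lower numbers for stronger inhibition), the only true number so far. Compound 1 `Cn1cc(C2=C(c3nn(CCCn4cncn4)c4ncccc34)C(=O)NC2=O)c2ccccc21` reads > 100000 nM, which is a limit. Compound 2 `Cn1cc(C2=C(c3n[nH]c4ncccc34)C(=O)NC2=O)c2ccccc21` reads > 100000 nM, also a limit.

Next is compound 4 `Cn1cc(C2=C(c3nn(CCCO)c4ncccc34)C(=O)NC2=O)c2ccccc21`, not yet measured, which carries 3-hydroxypropyl where compound 3 carries 3-(piperidin-1-yl)propyl: hydroxy in place of piperidin-1-yl on a saturated chain carbon, three bonds along the chain from an aromatic nitrogen. Going by the values given here, the closest precedent at this place, on a saturated chain carbon, three bonds along the chain from an aromatic nitrogen, is the exchange between 1H-1,2,4-triazol-1-yl and piperidin-1-yl, read in reverse from an at least 13-fold lower number from compound 1 to compound 3 (1.11 log units; beyond the scatter). Loss of the whole chain also bears on the case, read in reverse from an at least 13-fold lower number from compound 2 to compound 3 (1.11 log units; beyond the scatter). Both steps are large, but each has a limit at one end and so fixes only a minimum size, and neither involves hydroxy. Among the compounds with values here, in all three compounds, only the one with piperidin-1-yl gives a number, and none goes against this.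

A large move to a higher number in this assay is therefore expected, and compound 4 may also read only as a limit. The expected step is a 5.2-fold higher number from compound 3 to compound 4 (0.72 log units; beyond the scatter). For compound 4 the estimated value is 40000 nM, with an expected range of 12000 nM to 100000 nM.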

Compound 4, half-maximal inhibitory concentration: > 100000 nM
Compound 4 was reported as a limit; the forecaster's own chance of this, stated with the estimate: 45%; at least 2.5-fold (0.39 log units) between middle value and limit.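

In this assay, hydroxy in place of piperidin-1-yl on a saturated chain carbon, three bonds along the chain from an aromatic nitrogen, gives an at least 13-fold higher number from compound 3 to compound 4 (1.11 log units; beyond the scatter), and this size is only a minimum, as the reading for compound 4 is a limit. The propyl chain alone therefore does not give a number: compound 4 keeps the chain and ends it in hydroxy, so piperidin-1-yl is now the only one of the three end groups shown that gives a true value, and no compound shown goes against this. The steps among compound 1, compound 2 and compound 4 cannot be read, and these three compounds stay unranked at one shared ceiling: the limit of > 100000 nM in this assay, at which 3 of the 4 values shown sit.

As far as these compounds go, it remains open whether the gain in compound 3 depends on the ring of piperidin-1-yl or on its nitrogen, which a dimethylamino or a cyclohexyl group at the end of the same chain would separate. For the compounds shown here, also open are how a morpholine at this place or a shorter or longer chain carrying piperidin-1-yl would read, as compound 3 is still the only true number.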